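Aryl exchange on the shared core: compound 2 to compound 3

A few compounds are considered here, and "the series" means these few. Any claim that something is new, unique, unknown or untested is made for them only; others in the source may bear on it.

Compound 1 `c1cc(-c2ccn[nH]2)c2c(c1)C(c1ncc[nH]1)CC2`: in a functional assay on CHO cells for agonist activity at Alpha-1D adrenergic receptor (Homo sapiens), read by FLIPR and calcium flux (on this read-out higher numbers stand for an effect only at larger amounts of compound and lower numbers for an effect already at smaller amounts), compound 1 gives 336 nM.
Compound 2 `c1cncc(-c2cccc3c2CCC3c2ncc[nH]2)c1`: in this assay compound 2 gives only a limit, > 10000 nM.

Compound 2 thus sits at the limit of > 10000 nM in this assay, at which 1 of the 2 values shown sits, with no number of its own. For the measured compounds named here, the one measured step, an at least 29-fold higher number from compound 1 to compound 2 (1.47 log units; beyond the scatter), runs up to that limit. Compound 3 `Cn1cc(-c2cccc3c2CCC3c2ncc[nH]2)cn1` is the next change: 1-methyl-1H-pyrazol-4-yl in place of pyridin-3-yl on an aromatic carbon. As with compound 2, the entering ring of compound 3 carries no hydrogen-bond donor, and the large loss seen in an at least 29-fold higher number from compound 1 to compound 2 (1.47 log units; beyond the scatter) gives no ground to expect recovery. The step of an at least 1.4-fold lower number from compound 2 to compound 3 (0.15 log units; that floor lies within the scatter) is expected to stay within the scatter. Compound 3 is estimated at 7000 nM, range 1500 nM to 30000 nM, most likely again reported only as a limit.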

Compound 3, half-maximal effective concentration: > 10000 nM
Compound 3: no number, only a limit; the forecaster's own chance of this, stated with the estimate: 60%; middle value at least 1.4-fold (0.15 log units) away from the limit.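

Exchanging 1H-pyrazol-5-yl for 1-methyl-1H-pyrazol-4-yl gives an at least 29-fold higher number from compound 1 to compound 3 (1.47 log units; beyond the scatter), so a five-membered aromatic ring at this position does not by itself keep the number of compound 1. Compound 3 carries no hydrogen-bond donor on the entering ring, as compound 2 does not, and the step between these two cannot be read, both values being limits of the assay: the limit of > 10000 nM in this assay, at which 2 of the 3 values shown sit.

Open, from the compounds shown here alone, is whether the methyl or the point of attachment accounts for the loss. An unsubstituted 1H-pyrazol-4-yl on the same aromatic carbon would separate the two.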